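A few compounds are considered here, and "the series" means these few. Any claim that something is new, unique, unknown or untested is made for them only; others in the source may bear on it.

Three compounds of the series have been run in a functional assay on HL-60 cells (Homo sapiens) for cytotoxicity, read by MTT assay, with a stated time of 48 h; on this read-out higher numbers stand for weaker inhibition and lower numbers for stronger inhibition. Compound 2 `N#Cc1ccc(Cn2c(/C=C3\SC(=S)N(CC(=O)O)C3=O)nc3ccccc32)cc1` gives 7640 nM. Compound 1 `O=C(O)CN1C(=O)/C(=C/c2nc3ccccc3n2Cc2ccc(Br)cc2F)SC1=S` gives 6420 nM and compound 3 `O=C(O)CN1C(=O)/C(=C/c2nc3ccccc3n2Cc2ccc(C(F)(F)F)cc2)SC1=S` gives 3560 nM. Within the data shown here, compound 2 thus holds the highest of the three numbers, though the step of a 1.2-fold higher number from compound 1 to compound 2 (0.08 log units; within the scatter) lies within the scatter; only the step of a 2.1-fold lower number from compound 2 to compound 3 (0.33 log units; beyond the scatter) lies beyond it, and that one is modest.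

Compound 4 `O=C(O)CN1C(=O)/C(=C/c2nc3ccccc3n2Cc2ccc(F)c(F)c2)SC1=S` has not yet been measured. It differs from compound 2 by 3,4-difluorophenyl in place of 4-cyanophenyl on a saturated chain carbon bound to an aromatic nitrogen. Among the measured compounds shown here, every measured step in this assay touches the same ring on the same chain carbon: a 1.2-fold higher number from compound 1 to compound 2 (0.08 log units; within the scatter) and a 1.8-fold lower number from compound 1 to compound 3 (0.26 log units; within the scatter) both stay within the scatter, and a 2.1-fold lower number from compound 2 to compound 3 (0.33 log units; beyond the scatter) is the sole step beyond it. Swaps at this ring have so far moved the numbers little. Given that compound 2 gives 7640 nM, the step of a 1.4-fold lower number from compound 2 to compound 4 (0.14 log units; within the scatter) is expected to be small, at most a modest move to a lower number. For compound 4 the estimate in this assay is 5500 nM, with a range from 2500 nM to 12000 nM.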

Compound 4, half-maximal inhibitory concentration: 2740 nM
Compound 4: the middle estimate sits 2.0-fold (0.30 log units) above what was measured; low and high end bracket the measured number.
By their numbers in this assay, from the lowest: compounds 4, 3, 1 and 2 (each within the scatter of the next, the first and the last beyond it).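

In this assay, the swap of 4-cyanophenyl for 3,4-difluorophenyl on a saturated chain carbon bound to an aromatic nitrogen gives a 2.8-fold lower number from compound 2 to compound 4 (0.45 log units; beyond the scatter) and so shows a second step beyond the scatter at this position. The change from 4-bromo-2-fluorophenyl gives a 2.3-fold lower number from compound 1 to compound 4 (0.37 log units; beyond the scatter) and is also beyond the scatter, whereas the change from 4-(trifluoromethyl)phenyl gives a 1.3-fold lower number from compound 3 to compound 4 (0.11 log units; within the scatter) and sets no order between those two compounds. Among these compounds, compound 4 is therefore the only compound here with steps beyond the scatter to two others, and no measurement at hand accounts for these differences.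

The compounds shown leave open how an aminophenyl or a methoxyphenyl would read on this chain carbon. They also leave open whether a longer chain between the aromatic nitrogen and the ring keeps these steps.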